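The source may report more compounds than this note shows. Statements on the series, on what has been measured and on what is new or still open speak of the compounds shown alone.

Among the three compounds measured so far in an ADME assay on a cell-free system (plasma, Homo sapiens) (on this read-out higher numbers stand for a larger free fraction and lower numbers for a smaller free fraction), compound 1 (`CCNC(=O)Nc1nc2cc(-c3cccnc3)c(=O)n(C(C)C)c2s1`) stands highest, at 0.21. Two relatives differ from it only in the group on the aromatic nitrogen: compound 2 (`CCNC(=O)Nc1nc2cc(-c3cccnc3)c(=O)n(CC3CC3)c2s1`) gives 0.05 and compound 3 (`CCNC(=O)Nc1nc2cc(-c3cccnc3)c(=O)n(CC3CCCCC3)c2s1`) gives 0.02.

Compound 4 (`CCNC(=O)Nc1nc2cc(-c3cncc(OC)c3)c(=O)n(C(C)C)c2s1`) keeps the isopropyl group of compound 1 and changes a different place. The difference is methoxy in place of hydrogen on an aromatic carbon, so methoxy stands in place of hydrogen on an aromatic carbon, and pyridin-3-yl becomes 5-methoxypyridin-3-yl.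

Among the measured compounds shown here, no measured step tests a change at that place, so the available evidence is indirect. The three steps all concern the nitrogen group: a 4.2-fold lower number from compound 1 to compound 2 (0.62 log units; beyond the scatter), an 11-fold lower number from compound 1 to compound 3 (1.02 log units; beyond the scatter) and a 2.5-fold lower number from compound 2 to compound 3 (0.40 log units; beyond the scatter). They show that this assay responds to changes in this series, and in these three compounds each larger group goes with a lower number. From the compounds shown here alone, whether that trend carries over to a new group elsewhere on the molecule is unknown, so only a small lowering is expected here. The expected step is a 1.5-fold lower number from compound 1 to compound 4 (0.18 log units; within the scatter), which would stay within the scatter. The estimated value for compound 4 is 0.14, with an expected range from 0.07 to 0.24.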

Compound 4, unbound fraction: 0.08
The estimate for compound 4 lay 1.8-fold (0.24 log units) above the measured number; measured number inside the range.
By their numbers in this assay, from the lowest: compound 3; then compounds 2 and 4 (each within the scatter of the next); then compound 1.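

Placing methoxy on the pyridin-3-yl ring gives a 2.6-fold lower number from compound 1 to compound 4 (0.42 log units; beyond the scatter), so this assay responds to a change at this aromatic carbon as well, and not only to changes in the group on the aromatic nitrogen. The added group is small, with 2 heavy atoms and no ring, yet the step still lies beyond the scatter, which shows that even a small addition at this place can lower the free fraction. Nothing available here reports what lies behind this lowering, so the step stands as an observation without an explanation.

One compound cannot show whether the lowering is specific to methoxy or would also follow from another group at this place, such as a fluorine, a methyl, a hydroxyl or an amine. From the compounds shown here alone, it also remains open whether the same methoxy change would give a step of similar size with cyclopropylmethyl or cyclohexylmethyl on the aromatic nitrogen, or whether the effects of the two places would simply add together.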